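Notes on a weak series: methyl against trifluoromethyl

The source may report more compounds than this note shows. Statements on the series, on what has been measured and on what is new or still open speak of the compounds shown alone.

Compound 1 `O=S(=O)(Nc1ccc2oc(-c3ccccc3)nc2c1)c1cccc(C(F)(F)F)c1` and compound 2 `Cc1cccc(S(=O)(=O)Nc2ccc3oc(-c4ccccc4)nc3c2)c1` share one core; compound 3 `Cc1ccccc1S(=O)(=O)Nc1ccc(-c2nc3ccccc3o2)cc1` and compound 4 `O=S(=O)(Nc1ccc(-c2nc3ccccc3o2)cc1)c1ccccc1C(F)(F)F` share another, and the difference between the two cores is not broken down here. In an assay on cells for inhibition of HSP60/HSP10 (Homo sapiens), with a stated time of 60 min (on this read-out higher numbers stand for weaker inhibition and lower numbers for stronger inhibition), compound 1 gives only a limit of the assay, > 100000 nM. Compound 2 likewise gives only a limit, > 100000 nM. Going by the values given here, compound 3 gives the one number of the set, 85000 nM in this assay.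

The change from compound 2 to compound 1 is trifluoromethyl in place of methyl on an aromatic carbon. Its step, a step that the two limits leave unreadable from compound 2 to compound 1, cannot be sized because both values sit at the limit of > 100000 nM in this assay, at which 2 of the 3 values shown sit. The change from compound 3 to compound 4 is trifluoromethyl in place of methyl on an aromatic carbon; it is the same kind of change, not the same, since the entering group stands ortho to a large group in compound 4 and meta to a large group in compound 1.

Among the compounds with values here, with the earlier step unreadable, the only footing for compound 4 is the value of compound 3 in this assay, 85000 nM, together with the fact that both compounds carrying methyl or trifluoromethyl on the first core sit at the limit of > 100000 nM in this assay, at which 2 of the 3 values shown sit. The step from compound 3 to compound 4 is expected to be small, a 1.1-fold higher number from compound 3 to compound 4 (0.02 log units; within the scatter). Compound 4 is therefore estimated at 90000 nM, with a range from 30000 nM to 300000 nM, and a fair chance that only a limit is reported.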

Compound 4, half-maximal inhibitory concentration: 74000 nM
The estimate for compound 4 lay 1.2-fold (0.09 log units) above the measured number; low and high end bracket the measured number.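

Trifluoromethyl in place of methyl on an aromatic carbon, ortho to a large group, gives a 1.1-fold lower number from compound 3 to compound 4 (0.06 log units; within the scatter) in this assay, so on this core the change shows no readable effect on the read-out. As far as these compounds go, the corresponding step between compound 2 and compound 1 on the other core cannot be read, because both compounds give only a limit and not a number: the limit of > 100000 nM in this assay, at which 2 of the 4 values shown sit. This leaves one readable instance of the change, which shows that it is tolerated on a single core at this weak level of inhibition but does not show that the result carries over to the other core, where the size of the step remains unknown and the entering group does not stand in the same place.

The compounds shown leave open whether a group of a different kind at this place, such as an amine, a carboxylic acid or a longer chain like propyl, would move the read-out away from this weak range on either core. They also leave open how much of any difference between compounds on the two cores belongs to the cores themselves, as no pair shown differs in that alone.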